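The source may report more compounds than this note shows. Statements on the series, on what has been measured and on what is new or still open speak of the compounds shown alone.

Measured compounds in a toxicity assay on HeLa cells (Homo sapiens) for cytotoxicity, read by colorimetric assay, with a stated time of 72 h; a lower number here means that less compound is tolerated, a higher number that more compound is tolerated:
Compound 1 `N#Cc1cccc(N2CCN(c3nc(=O)c4cc(C(F)(F)F)cc([N+](=O)[O-])c4s3)CC2)c1` gives > 108000 nM, which is a limit of the assay rather than a number.
Compound 2 `CN(C(=O)CN1CCN(c2nc(=O)c3cc(C(F)(F)F)cc([N+](=O)[O-])c3s2)CC1)c1ccccc1` gives 70300 nM.

For the measured compounds named here, compound 2 holds the only actual number here; the other value is a limit. Compound 3 `O=C(CN1CCN(c2nc(=O)c3cc(C(F)(F)F)cc([N+](=O)[O-])c3s2)CC1)Nc1ccccn1` differs from compound 2 in one place: (pyridin-2-yl)amino in place of methyl(phenyl)amino on a carbonyl carbon. Going by the values given here, the single measured step, an at least 1.5-fold lower number from compound 1 to compound 2 (0.18 log units; that floor lies within the scatter), alters a different part of the shared core and barely leaves the scatter, so it bears only loosely on this change. No movement beyond the scatter is expected. The step expected from this change, a 1.0-fold lower number from compound 2 to compound 3 (0.00 log units; within the scatter), should stay within the scatter. Compound 3 is estimated at 70000 nM, between 25000 nM and 150000 nM.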

Compound 3, half-maximal cytotoxic concentration: 44500 nM
Compound 3: the middle estimate sits 1.6-fold (0.20 log units) above what was measured, within the range that was stated.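

In this assay, (pyridin-2-yl)amino in place of methyl(phenyl)amino on the carbonyl carbon gives a 1.6-fold lower number from compound 2 to compound 3 (0.20 log units; within the scatter), so this position accepts a ring with a hetero atom and an added hydrogen-bond donor without leaving the scatter. For the compounds shown here, the larger replacement of 3-cyanophenyl gives an at least 2.4-fold lower number from compound 1 to compound 3 (0.38 log units; beyond the scatter), the first step here that clears the scatter. Compound 1 sits at a limit of the assay, so the true size of that step is unknown: the limit of > 108000 nM in this assay, at which 1 of the 3 values shown sits.

The methyl and ring-nitrogen differences remain tangled, and phenylamino on the same carbonyl carbon would separate them. From the compounds shown here alone, whether an alkylamine there would shift the number also remains open.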